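This account rests on a few compounds, and the source may have more. Where it says the series, first, only, none or still open, it means among the compounds named here.

Compound 1, `CCOC(=O)c1cnc(N2CCN(Cc3ccccc3F)CC2)nc1Oc1c(C)cc(-c2ccc(C#N)cc2)cc1C`: in an ADME assay on MT4 cells (Homo sapiens) for cytotoxicity, read by MTT assay, with a stated time of 4 days (on this read-out lower numbers stand for higher toxicity in this test and higher numbers for lower toxicity in this test), compound 1 gives > 125000 nM, which is a limit of the assay and not a number.
Compound 2, `CCOC(=O)c1cnc(N2CCN(Cc3cccc(C(=O)OC)c3)CC2)nc1Oc1c(C)cc(-c2ccc(C#N)cc2)cc1C`: in this assay compound 2 gives > 125000 nM, also a limit.
Compound 3, `CCOC(=O)c1cnc(N2CCN(Cc3ccc(Br)cc3)CC2)nc1Oc1c(C)cc(-c2ccc(C#N)cc2)cc1C`: in this assay compound 3 gives > 125000 nM, again a limit.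

Compound 1 therefore stands only at a limit in this assay, and the two further values shown are limits as well; (the limit of > 125000 nM in this assay, at which 3 of the 3 values shown sit). The three steps among the measured compounds, a step that the two limits leave unreadable from compound 1 to compound 2, a step that the two limits leave unreadable from compound 1 to compound 3 and a step that the two limits leave unreadable from compound 2 to compound 3, are all unreadable for that reason, so none of them gives a readable size that bears on the change to compound 4.

Compound 4, `CCOC(=O)c1cnc(N2CCN(Cc3ccc(S(N)(=O)=O)cc3)CC2)nc1Oc1c(C)cc(-c2ccc(C#N)cc2)cc1C`, differs from compound 1 in this way: 4-sulfamoylphenyl in place of 2-fluorophenyl on a saturated chain carbon bound to an amine nitrogen in a ring. With every measured step unreadable, the expectation rests on the three limits alone, and compound 4 is expected to sit at the limit too, with no step beyond the scatter: a number no higher from compound 1 to compound 4 (the limit leaves the size open). The estimate for compound 4 in this assay is 125000 nM, with a range from 60000 nM to 300000 nM.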

Compound 4, half-maximal cytotoxic concentration: >= 7930 nM
Compound 4: a limit, no number (the forecaster's own chance of this, stated with the estimate: 85%); the middle value is on the limit's open side.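

In this assay compound 4 gives >= 7930 nM, which is a limit of the assay and not a number. Within the data shown here, no step to compound 4 from compound 1, compound 2 or compound 3 can be read. The compounds shown leave open where any of the four actual values lies, and whether 4-sulfamoylphenyl in place of 2-fluorophenyl shifts the value at all.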